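Dropping the methylcarbamoyl group: compound 4

The source may hold more compounds than are shown below. What is called first, only, known or untested is meant among the compounds shown, and "the series" means these compounds.

Three members of the series have been run in a functional assay on Huh-7 cells (Homo sapiens) for antiproliferative activity, read by CCK-8 assay, with a stated time of 72 h; a higher number here means a weaker inhibitor of growth, a lower number a stronger inhibitor of growth. Compound 1 `CC[C@@H]1C(=O)N(C)c2cnc(-n3ccc4cc(C(=O)NC(C)C)ccc43)nc2N1C1CCCC1` gives 1660 nM. Compound 2 `CCCCNC(=O)c1ccc2c(ccn2-c2ncc3c(n2)N(C2CCCC2)[C@H](CC)C(=O)N3C)c1` gives 683 nM, and compound 3 `CC[C@@H]1C(=O)N(C)c2cnc(-n3ccc4cc(C(=O)NC)ccc43)nc2N1C1CCCC1` gives 842 nM. On these numbers compound 3 sits between the other two, yet its gap to compound 2 and its gap to compound 1 are both within the scatter, so the three are not separated with confidence.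

The next compound, compound 4 `CC[C@@H]1C(=O)N(C)c2cnc(-n3ccc4ccccc43)nc2N1C1CCCC1`, differs from compound 3 in one place: hydrogen in place of methylcarbamoyl on an aromatic carbon.

The measured steps bear on this only in part. a 2.4-fold lower number from compound 1 to compound 2 (0.39 log units; beyond the scatter) and a 2.0-fold lower number from compound 1 to compound 3 (0.29 log units; within the scatter) exchange the group on the amide nitrogen, and a 1.2-fold higher number from compound 2 to compound 3 (0.09 log units; within the scatter) shortens it; in every case the amide itself, with its donor and acceptor, stays in place, and the numbers move modestly or not beyond the scatter. Among the compounds with values here, no measured step removes the whole group, so the step to compound 4 is untested in kind. Removing a donor and an acceptor that all three measured compounds share is taken here as more likely to weaken than to strengthen growth inhibition, with wide uncertainty.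

Compound 4 is therefore expected to give about 2200 nM in this assay, with a range of 650 nM to 7500 nM. The expected step is a 2.6-fold higher number from compound 3 to compound 4 (0.42 log units; beyond the scatter), beyond the scatter but not large.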

Compound 4, concentration for 50% growth inhibition: 4690 nM
For compound 4 the middle estimate is 2.1-fold (0.33 log units) below the measured one; measured number inside the range.
By their numbers in this assay, from the lowest: compounds 2, 3 and 1 (each within the scatter of the next, the first and the last beyond it); then compound 4.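

In this assay, removing the whole carbamoyl group from this aromatic carbon raises the number against each of the three amides: a 5.6-fold higher number from compound 3 to compound 4 (0.75 log units; beyond the scatter), a 6.9-fold higher number from compound 2 to compound 4 (0.84 log units; beyond the scatter) and a 2.8-fold higher number from compound 1 to compound 4 (0.45 log units; beyond the scatter). The earlier steps shown here only exchanged the group on the amide nitrogen, whereas these steps show that, across the four compounds and with none going against it, having a carbamoyl group at this place goes with a lower number than having hydrogen there. No evidence on the reason for this rise is at hand.

The compounds shown leave open whether the difference follows the amide hydrogen or the carbonyl, a question that a dimethylamide, a nitrile or a carboxylic acid on this aromatic carbon would help to separate. Also open, on these data alone, is whether a chain longer than butyl on the amide nitrogen, or one ending in an amine, would give a number outside the span of compound 1, compound 2 and compound 3.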